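Adding a Methyl Where the Assay Already Reports Only a Limit

The source may hold more compounds than are shown below. What is called first, only, known or untested is meant among the compounds shown, and "the series" means these compounds.

Compound 1, `CCOc1ccc(-n2nncc2CN2C(=O)C3(C(C#N)=C(N)Oc4c(N)cc5nc6ccccc6nc5c43)c3ccccc32)cc1`, gives in a functional assay on MCF7 cells (Homo sapiens) for antiproliferative activity, read by MTT assay, with a stated time of 48 h (a lower number here means a stronger inhibitor, a higher number a weaker inhibitor), a value of 26800 nM.
Compound 2, `CCc1cccc(C)c1-n1nncc1CN1C(=O)C2(C(C#N)=C(N)Oc3c(N)cc4nc5ccccc5nc4c32)c2ccccc21`, gives in this assay only a limit, > 50000 nM.

Compound 2 stands at a limit of the assay, not at a number. Among the compounds with values here, the one measured step, an at least 1.8-fold higher number from compound 1 to compound 2 (0.27 log units; that floor lies within the scatter), comes from changing the group on the aromatic nitrogen, and its floor lies within the scatter, so it cannot show how far past that edge compound 2 sits. Compound 3, `CCc1cccc(CC)c1-n1nncc1CN1C(=O)C2(C(C#N)=C(N)Oc3c(N)cc4nc5ccccc5nc4c32)c2ccccc21`, differs from compound 2 by methyl in place of hydrogen on a saturated chain carbon bound to an aromatic carbon. Within the data shown here, this is a smaller change than the measured one, and nothing here measures an added methyl on such a chain, so the step from compound 1 to compound 2 is the only guide, and it marks where compound 2 stands rather than what this change does. The expectation is therefore a step that the limit leaves unreadable from compound 2 to compound 3, with the assay likely once more reporting only a limit. Compound 3 is estimated at 65000 nM, within 22000 nM to 200000 nM.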

Compound 3, half-maximal inhibitory concentration: > 50000 nM
Compound 3: only a limit was reported; the forecaster's own chance of this, stated with the estimate: 75%; the middle value does not contradict the limit.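

In this assay compound 3 gives > 50000 nM, which is a limit of the assay and not a number. Within the data shown here, changing methyl to ethyl on this saturated chain carbon, which turns 2-ethyl-6-methylphenyl into 2,6-diethylphenyl, therefore does not bring a measured number back, and the step between these two compounds cannot be read: the limit of > 50000 nM in this assay, at which 2 of the 3 values shown sit. The one step that can be stated is an at least 1.8-fold higher number from compound 1 to compound 3 (0.27 log units; that floor lies within the scatter), and as a floor it shows only that 2,6-diethylphenyl, like 2-ethyl-6-methylphenyl, gives no number in this assay.

As far as these compounds go, how far past the limit either compound sits remains open. So does whether a propyl chain or an amine at this carbon would give a number inside the range of the assay.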